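A few compounds are considered here, and "the series" means these few. Any claim that something is new, unique, unknown or untested is made for them only; others in the source may bear on it.

Compound 1 `C[S+]([O-])c1c(F)c(N)c2c(=O)cc(-c3ccc(N)c(F)c3)oc2c1F`: in a functional assay on HeLa cells (Homo sapiens) for cytotoxicity, read by neutral red uptake, with a stated time of 3 days (a lower number here means a stronger inhibitor, a higher number a weaker inhibitor), compound 1 reaches only the limit of > 100000 nM.
Compound 2 `COc1c(F)c(N)c2c(=O)cc(-c3ccc(N)c(F)c3)oc2c1F`: in this assay compound 2 gives 34000 nM.
Compound 3 `CN(C)c1c(F)c(N)c2c(=O)cc(-c3ccc(N)c(F)c3)oc2c1F`: in this assay compound 3 reaches only the limit of > 100000 nM.

Compound 3 therefore stands at the limit of this assay, not at a number; it shares that limit with compound 1 (the limit of > 100000 nM in this assay, at which 2 of the 3 values shown sit). Among the measured compounds shown here, the only readable step into compound 3 is an at least 2.9-fold higher number from compound 2 to compound 3 (0.46 log units; beyond the scatter), which tells that the dimethylamino compound is weaker than the methoxy compound, without saying how much weaker. The step that the two limits leave unreadable from compound 1 to compound 3 stays unreadable, since both ends sit at the limit.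

Compound 4 `CN(C)CCCC(=O)OCc1c(F)c(N)c2c(=O)cc(-c3ccc(N)c(F)c3)oc2c1F` takes the step ((((3-(dimethylamino)propyl)carbonyl)oxy)methyl in place of dimethylamino on an aromatic carbon). For the measured compounds named here, no measured step involves the entering group, and the one step that ends at compound 3 gives only a lower bound. The account can therefore lean on nothing but the position of compound 3 at the limit, so a sizeable change in this assay in either direction cannot be ruled out, and none beyond the scatter is expected with confidence.

Compound 4 is expected to stay near the limit, with a number no higher from compound 3 to compound 4 (the limit leaves the size open) as the expected step. The estimate for compound 4 in this assay is 100000 nM, expected to lie between 20000 nM and 300000 nM.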

Compound 4, half-maximal inhibitory concentration: 4500 nM
Beside the measured number, compound 4's estimate is 22-fold (1.35 log units) above it, and the stated range ends above it.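

At this position, on an aromatic carbon ortho to two fluoro groups, the (((3-(dimethylamino)propyl)carbonyl)oxy)methyl group gives, in this assay, an at least 22-fold lower number from compound 3 to compound 4 (1.34 log units; beyond the scatter) and an at least 22-fold lower number from compound 1 to compound 4 (1.34 log units; beyond the scatter). Among the compounds shown here, the step with a measured number at both ends is a 7.6-fold lower number from compound 2 to compound 4 (0.88 log units; beyond the scatter), so compound 4 is the strongest inhibitor of the four and the position takes a far larger group than the earlier compounds carried, with the number falling, not rising. Compound 1 and compound 3 each remain at a limit, so the steps from them give only a lower bound on the size of the change: the limit of > 100000 nM in this assay, at which 2 of the 4 values shown sit.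

The compounds shown leave open which part of the entering group goes with the step, whether the carbonyl and its oxygen, the propyl chain or the terminal dimethylamino, since all of them enter together. A hydroxymethyl group, a carboxylic acid at the end of the chain, an amide in place of the ester or a longer chain would each separate these parts, and none of these stands among the compounds here.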